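The source may hold more compounds than are shown below. What is called first, only, known or untested is meant among the compounds shown, and "the series" means these compounds.

Values measured so far in a functional assay on KB cells (Homo sapiens) for antiproliferative activity, read by MTT assay, with a stated time of 72 h (a higher number here means a weaker inhibitor, a lower number a stronger inhibitor), are these:

Compound 1 `CCOC(=O)c1cc(-c2cc(OC)c(OC)c(OC)c2)c(-c2ccc(OC)c(O)c2)s1`: 1250 nM
Compound 2 `COc1ccc(-c2sccc2-c2cc(OC)c(OC)c(OC)c2)cc1OCc1ccccc1`: > 100000 nM (a limit of the assay)
Compound 3 `CCOC(=O)c1cc(-c2ccc(OC)cc2)c(-c2cc(OC)c(OC)c(OC)c2)s1`: 10200 nM

Compound 3, at 10200 nM, holds the higher of the two actual numbers, and compound 1, at 1250 nM, lies lower by more than the scatter. Compound 2 gives only the limit > 100000 nM in this assay and no number.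

Compound 4 `CCOC(=O)c1cc(-c2ccc(OC)c(OCc3ccccc3)c2)c(-c2cc(OC)c(OC)c(OC)c2)s1` departs from compound 3 by a single change, (benzyloxy in place of hydrogen on an aromatic carbon), with benzyloxy in place of hydrogen on an aromatic carbon, ortho to a methoxy group. Among the compounds with values here, no measured pair shows this change alone. Within the data shown here, compound 2, the only measured compound with a benzyloxy group, reads > 100000 nM as a limit, although it also differs from compound 4 elsewhere. A moderate weakening in this assay is therefore expected, with wide uncertainty. The expected step is a 2.5-fold higher number from compound 3 to compound 4 (0.39 log units; beyond the scatter), towards a higher number. Compound 4 is estimated at 25000 nM, with an expected range of 6000 nM to 90000 nM in this estimate.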

Compound 4, half-maximal inhibitory concentration: > 100000 nM
Compound 4: no number, only a limit (the forecaster's own chance of this, stated with the estimate: 25%); middle value at least 4.0-fold (0.60 log units) away from the limit.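

In this assay, benzyloxy in place of hydrogen on the aromatic carbon ortho to a methoxy group gives an at least 9.8-fold higher number from compound 3 to compound 4 (0.99 log units; beyond the scatter). Within the data shown here, this is the first measured pair to isolate the change, and it shows that this position does not take benzyloxy without a clear loss of antiproliferative activity. Compound 4 gives > 100000 nM, which is a limit of the assay and not a number, so the step sets only a lower bound and its full size cannot be read: the limit of > 100000 nM in this assay, at which 2 of the 4 values shown sit.

The compounds shown leave open whether a smaller group at this position, such as a fluorine atom, an amine or an ethoxy group, would be better kept. Among these compounds, with only one pair carrying this change, it also remains unknown whether benzyloxy would have the same effect on a different core.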